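The compounds below may be only part of what the source reports. "The series", "measured", "known", "first", "only" and "open" are said of these compounds alone.

Values so far in a functional assay on CEM-SS cells (Homo sapiens) for cytotoxicity; on this read-out lower numbers stand for stronger inhibition and higher numbers for weaker inhibition:
- compound 1 `Nc1nc2cc(Cl)c(Cl)cc2n1Cc1ccc(Cl)c(Cl)c1`: 30000 nM
- compound 2 `Clc1ccc(Cn2c(Cl)nc3cc(Cl)c(Cl)cc32)cc1`: > 100000 nM

Compound 2 reads > 100000 nM, which is a limit of the assay and not a number. This is the limit of > 100000 nM in this assay, at which 1 of the 2 values shown sits.

Compound 3 `Clc1ccc(Cn2c(Cl)nc3cc(Cl)c(Cl)cc32)cc1Cl` departs from compound 2 by a single change, chloro in place of hydrogen on an aromatic carbon, ortho to a chloro group and meta to a large group.

For the measured compounds named here, no measured step isolates this change, so any expectation for it in this assay rests on thin ground. Going by the values given here, compound 1 gives 30000 nM, the only numeric value so far, which shows that a number can be obtained. A small step toward stronger inhibition is expected, possibly none beyond the scatter, and compound 3 may well return only a limit too. The expected step is an at least 1.4-fold lower number from compound 2 to compound 3 (0.15 log units; that floor lies within the scatter). The estimated value for compound 3 is 70000 nM, with an expected range of 25000 nM to 200000 nM.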

Compound 3, half-maximal inhibitory concentration: > 100000 nM
Compound 3 gave a limit, no number (the forecaster's own chance of this, stated with the estimate: 55%); middle value at least 1.4-fold (0.15 log units) from the limit.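

In this assay compound 3 reads > 100000 nM, a limit of the assay and not a number, so the step for chloro in place of hydrogen on this aromatic carbon, ortho to a chloro group, cannot be read, and the limit now holds most of the values shown: the limit of > 100000 nM in this assay, at which 2 of the 3 values shown sit. The readable comparison lies at the other place of change, where chloro in place of amino on an aromatic carbon gives an at least 3.3-fold higher number from compound 1 to compound 3 (0.52 log units; beyond the scatter). This gives the exchange of amino for chloro a direction on this read-out, with the printed size as a floor, while the added chloro still has none.

As far as these compounds go, whether the added chloro changes cytotoxicity at all stays open, since both compounds carrying the chloro in place of amino sit at the limit, and the effect could be read only where a number is returned, as with the amino group of compound 1. Also open, from the compounds shown here alone, is whether the number depends on amino itself, which a methylamino or hydroxyl group at that place would test.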